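Swapping the Side-Chain Amide for a Trimethoxyphenyl Group

A few compounds are considered here, and "the series" means these few. Any claim that something is new, unique, unknown or untested is made for them only; others in the source may bear on it.

Compound 1 `COc1cc(-c2nc3cc(/C=C4\SC(=O)NC4=O)ccc3[nH]2)cc(OC)c1OC` gives 1670 nM in a functional assay on HeLa cells (Homo sapiens) for inhibition, read by MTT assay, with a stated time of 48 h; a lower number here means a stronger inhibitor, a higher number a weaker inhibitor.
Compound 2 `COc1cc(-c2nc3cc(/C=C4\SC(=O)N(CC(=O)N5CCCCC5)C4=O)ccc3[nH]2)cc(OC)c1OC` gives 23300 nM in this assay.
Compound 3 `COc1cc(OC)c(-c2nc3cc(/C=C4\SC(=O)N(CC(=O)N5CCCCC5)C4=O)ccc3[nH]2)cc1OC` gives 6890 nM in this assay.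

Compound 2 has the highest number of the three, so it is the weakest inhibitor of this small set: a 14-fold higher number from compound 1 to compound 2 (1.14 log units; beyond the scatter), and a 3.4-fold lower number from compound 2 to compound 3 (0.53 log units; beyond the scatter). Compound 4 `COc1cc(CN2C(=O)S/C(=C\c3ccc4[nH]c(-c5cc(OC)c(OC)c(OC)c5)nc4c3)C2=O)cc(OC)c1OC` keeps the core of compound 2 and changes only the chain on the ring nitrogen: 3,4,5-trimethoxyphenyl in place of (piperidin-1-yl)carbonyl on a saturated chain carbon bound to an amide-type nitrogen in a ring.

Among the measured compounds shown here, no measured step makes this exact exchange. The closest guide is the step from compound 1 to compound 2, where attaching the whole ((piperidin-1-yl)carbonyl)methyl chain to that nitrogen cost a large amount in this assay. Whether a 3,4,5-trimethoxyphenyl group on that same chain carbon is tolerated better, worse or about the same is not shown by any compound here. The expectation for compound 4 is therefore a number somewhere between those of compound 1 and compound 2, estimated as 8000 nM (range 2000 nM to 35000 nM), which would mean an expected step of a 2.9-fold lower number from compound 2 to compound 4 (0.46 log units; beyond the scatter).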

Compound 4, half-maximal inhibitory concentration: 2240 nM
Beside the measured number, compound 4's estimate is 3.6-fold (0.55 log units) above it; measured number inside the range.
By their numbers in this assay, from the lowest: compounds 1 and 4 (each within the scatter of the next); then compound 3; then compound 2.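

In this assay, the exchange on the saturated chain carbon bound to the amide-type nitrogen in the ring gives a 10-fold lower number from compound 2 to compound 4 (1.02 log units; beyond the scatter), so the group carried by this chain matters, not only the presence of a chain. The large loss seen with the ((piperidin-1-yl)carbonyl)methyl chain does not hold for every chain: compound 4 gives 2240 nM and compound 1, with hydrogen on that nitrogen, gives 1670 nM, two values within the scatter of each other. Nothing measured here explains the gap between the two groups.

Still open, as far as these compounds go, is whether a chain ending in a plain phenyl ring, an amine or a carboxylic acid would behave like compound 4 or like compound 2. Also open, from the compounds shown here alone, is whether 2,4,5-trimethoxyphenyl on the aromatic carbon, which lowers the number in compound 3, would do so alongside the chain of compound 4.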